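Fluoro in place of methoxy on the amide aryl ring

This account rests on a few compounds, and the source may have more. Where it says the series, first, only, none or still open, it means among the compounds named here.

Compound 1, `O=C(Nc1cccc(-c2oc3cc(-c4ccc(F)cc4)ccc3c(=O)c2O)c1)c1ccc(F)cc1`, gives 9280 nM in a functional assay on HepG2 cells (Homo sapiens) for antiproliferative activity, read by CCK-8 assay, with a stated time of 72 h; a higher number here means a weaker inhibitor, a lower number a stronger inhibitor.
Compound 2, `O=C(Nc1cccc(-c2oc3cc(-c4ccc(F)cc4)ccc3c(=O)c2O)c1)c1ccc(F)cc1F`, gives 26400 nM.
Compound 3, `COc1cccc(C(=O)Nc2cccc(-c3oc4cc(-c5ccc(F)cc5)ccc4c(=O)c3O)c2)c1`, gives 9950 nM.

Compound 3 stands second highest of these three numbers. Its nearest neighbour is compound 1, since a 1.1-fold higher number from compound 1 to compound 3 (0.03 log units; within the scatter); its furthest is compound 2, since a 2.7-fold lower number from compound 2 to compound 3 (0.42 log units; beyond the scatter). Compound 4, `O=C(Nc1cccc(-c2oc3cc(-c4ccc(F)cc4)ccc3c(=O)c2O)c1)c1cccc(F)c1`, differs from compound 3 in one place: fluoro in place of methoxy on an aromatic carbon. Among the measured compounds shown here, two measured steps bear on this. Replacing one aryl group on the carbonyl by another gave a 1.1-fold higher number from compound 1 to compound 3 (0.03 log units; within the scatter), while adding a fluoro to that ring gave a 2.8-fold higher number from compound 1 to compound 2 (0.45 log units; beyond the scatter). A small or no step beyond the scatter is therefore expected here, a 1.1-fold higher number from compound 3 to compound 4 (0.02 log units; within the scatter). Compound 4 is estimated at 10500 nM, with a range from 5000 nM to 22000 nM.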

Compound 4, half-maximal inhibitory concentration: 15500 nM
Compound 4: the middle estimate sits 1.5-fold (0.17 log units) below what was measured; the measured number falls inside the stated range.
By their numbers in this assay, from the lowest: compounds 1, 3, 4 and 2 (each within the scatter of the next, the first and the last beyond it).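

Fluoro in place of methoxy at this position gives a 1.6-fold higher number from compound 3 to compound 4 (0.19 log units; within the scatter), so the two groups cannot be told apart here. Also, 3-fluorophenyl in place of 4-fluorophenyl gives a 1.7-fold higher number from compound 1 to compound 4 (0.22 log units; within the scatter), and 3-fluorophenyl in place of 2,4-difluorophenyl gives a 1.7-fold lower number from compound 2 to compound 4 (0.23 log units; within the scatter). Compound 4 therefore cannot be separated from any of the other three compounds, and the amide aryl ring has so far accepted these small changes with little measurable effect.

Nothing available explains these small steps. Going by these compounds, how an amine or a carboxylic acid at this position would read in this assay remains open.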